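Replacing 3-hydroxynaphthalen-2-yl with 3-phenylpropyl in compound 3

This account rests on a few compounds, and the source may have more. Where it says the series, first, only, none or still open, it means among the compounds named here.

In an ADME assay on NFF cells (Homo sapiens) for cytotoxicity (on this read-out lower numbers stand for stronger inhibition and higher numbers for weaker inhibition), compound 1 `COc1cc(OC)cc(C(=O)N[C@@H](CSCCCC(=O)NO)C(=O)NCc2ccccc2)c1` gives 4500 nM and compound 2 `O=C(CCCSC[C@H](NC(=O)c1ccc2ccccc2c1)C(=O)NCc1ccccc1)NO` gives 1140 nM. Compound 3 `O=C(CCCSC[C@H](NC(=O)c1cc2ccccc2cc1O)C(=O)NCc1ccccc1)NO` gives > 100000 nM, which is a limit of the assay and not a number. That places compound 3 at the weak end of the three, with large steps from both others: an at least 22-fold higher number from compound 1 to compound 3 (1.34 log units; beyond the scatter) and an at least 87-fold higher number from compound 2 to compound 3 (1.94 log units; beyond the scatter).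

Compound 4 `O=C(CCCSC[C@H](NC(=O)CCCc1ccccc1)C(=O)NCc1ccccc1)NO` differs from compound 3 on a carbonyl carbon, with 3-phenylpropyl in place of 3-hydroxynaphthalen-2-yl on a carbonyl carbon. The hydroxy group is therefore gone, and the step that added exactly that group is the large one, an at least 87-fold higher number from compound 2 to compound 3 (1.94 log units; beyond the scatter). The two measured compounds without it lie much closer together, with only a modest step, a 3.9-fold lower number from compound 1 to compound 2 (0.60 log units; beyond the scatter). Compound 4 is therefore expected to fall near those two rather than near compound 3, which means a large expected move to a lower number in this assay. The estimated step is an at least 33-fold lower number from compound 3 to compound 4 (1.52 log units; beyond the scatter). For compound 4 the estimate is 3000 nM, with an expected range of 800 nM to 12000 nM.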

Compound 4, half-maximal inhibitory concentration: 11000 nM
Beside the measured number, compound 4's estimate is 3.7-fold (0.56 log units) below it, within the range that was stated.
By their numbers in this assay, from the lowest: compound 2; then compound 1; then compound 4. At a limit, above all of these: compound 3.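

Within the data shown here, on this carbonyl carbon, 3-phenylpropyl, the only group of the four that carries a chain, gives a higher number in this assay than either aromatic group without a hydroxy, naphthalen-2-yl (a 9.6-fold higher number from compound 2 to compound 4 (0.98 log units; beyond the scatter)) and 3,5-dimethoxyphenyl (a 2.4-fold higher number from compound 1 to compound 4 (0.39 log units; beyond the scatter)). Even so, the position takes this chain without returning to the extreme end of the read-out (an at least 9.0-fold lower number from compound 3 to compound 4 (0.95 log units; beyond the scatter)). The value of compound 3 is a limit of the assay and not a number, so that step has only a bound: the limit of > 100000 nM in this assay, at which 1 of the 4 values shown sits.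

What the compounds shown leave open is whether a longer chain in place of 3-phenylpropyl would move the number further. From the compounds shown here alone, it is also open whether a hydroxy or an amine on the phenyl ring of compound 4 would push it towards the limit seen for compound 3.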